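This account rests on a few compounds, and the source may have more. Where it says the series, first, only, none or still open, it means among the compounds named here.

In an ADME assay on microsomes from liver (Mus musculus, strain CD-1) for metabolic stability, read by LC-MS, tested at 2 uM (a lower number here means that the compound disappears faster, a higher number that the compound lasts longer), compound 3 `Cn1ccc2ccc(-c3cc(Nc4cnccc4C(=O)NCC4COCCN4)cc4nccnc34)cc21` gives > 1 h, which is a limit of the assay and not a number. Its standing among the measured compounds is the limit of > 1 h in this assay, at which 1 of the 3 values shown sits. Compound 1 `CN(C)C(=O)c1ccncc1Nc1cc(-c2ccc3ccn(C)c3c2)c2nccnc2c1` gives 0.35 h and compound 2 `CC(=O)N1CCCC(NC(=O)c2ccncc2Nc2cc(-c3ccc4ccn(C)c4c3)c3nccnc3c2)C1` gives 0.4 h, two values within the scatter of each other.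

Compound 4 `CC(=O)N1CC(CNC(=O)c2ccncc2Nc2cc(-c3ccc4ccn(C)c4c3)c3nccnc3c2)C1` has 1-acetylazetidin-3-yl in place of morpholin-3-yl on a saturated chain carbon bound to an amide-type nitrogen.

For the measured compounds named here, three measured steps bear on this change. The acetylated ring of compound 2 gave a 1.1-fold higher number from compound 1 to compound 2 (0.06 log units; within the scatter). The morpholine-bearing side chain of compound 3 gave an at least 2.8-fold higher number from compound 1 to compound 3 (0.45 log units; beyond the scatter), and the direct exchange of the two side chains gave an at least 2.5-fold higher number from compound 2 to compound 3 (0.39 log units; beyond the scatter). Compound 4 gives up morpholin-3-yl and carries an acetylated ring, as compound 2 does, so this assay is expected to return a lower number, reversing a step of about that last size.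

The expected step is an at least 2.0-fold lower number from compound 3 to compound 4 (0.30 log units; that floor lies within the scatter). For compound 4 the estimate is 0.5 h, with an expected range of 0.25 h to 1 h.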

Compound 4, half-life: > 1 h
Compound 4: only a limit was reported; the forecaster's own chance of this, stated with the estimate: 15%; middle value at least 2.0-fold (0.30 log units) away from the limit.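

In this assay compound 4 gives > 1 h, which is a limit of the assay and not a number. Morpholin-3-yl is therefore not required at this place, on a saturated chain carbon bound to an amide-type nitrogen: with 1-acetylazetidin-3-yl there, the series shows an at least 2.5-fold higher number from compound 2 to compound 4 (0.39 log units; beyond the scatter) and an at least 2.8-fold higher number from compound 1 to compound 4 (0.45 log units; beyond the scatter), so an acetylated ring does not by itself keep the number at the level of compound 2. The step from compound 3 to compound 4 cannot be read, and the comparison of these two side chains stops at the assay limit: the limit of > 1 h in this assay, at which 2 of the 4 values shown sit.

On these data alone, how far compound 3 and compound 4 each lie past that limit remains open, as does which of the two lasts longer. Also open, as far as these compounds go, is how a carboxylic acid or a free azetidine amine at this place would read in this assay.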